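The compounds below may be only part of what the source reports. "The series", "measured", "known", "first", "only" and "open" are said of these compounds alone.

Compound 1 `COC(=O)[C@@]1(C)CCC=C2[C@@H]1CC[C@@H](C)[C@]2(C)Cc1c(C)[nH]c2ccc(Br)cc12` — 11000 nM
Compound 2 `COC(=O)[C@@]1(C)CCC=C2[C@@H]1CC[C@@H](C)[C@]2(C)Cc1c(C)[nH]c2ccc(Cl)cc12` — 12000 nM
Compound 3 `COC(=O)[C@@]1(C)CC[C@@H]2C3=C1CC[C@@H](C)[C@]3(C)Cc1c2[nH]c2c(Br)cccc12` — 18000 nM

All three were tested in a functional assay on HeLa cells (Homo sapiens) for inhibition, read by sulforhodamine B assay, with a stated time of 48 h; a higher number here means a weaker inhibitor of growth, a lower number a stronger inhibitor of growth. Compound 1 and compound 2 share a core and differ by chloro in place of bromo on an aromatic carbon; this change gave a 1.1-fold higher number from compound 1 to compound 2 (0.04 log units; within the scatter). Compound 3 rests on a different core, and the difference between the two cores is not broken down here. In this assay compound 3 gives 18000 nM, which lies within the scatter of the values of compound 1 and compound 2.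

Compound 4 `COC(=O)[C@@]1(C)CC[C@@H]2C3=C1CC[C@@H](C)[C@]3(C)Cc1c2[nH]c2c(Cl)cccc12` is not yet measured. It differs from compound 3 by chloro in place of bromo on an aromatic carbon, the same kind of change as that from compound 1 to compound 2, though here the aromatic carbon sits in a fused system of five rings, ortho and meta to a fused ring, rather than in a system of two rings, meta and para to a fused ring. Because the earlier change gave a 1.1-fold higher number from compound 1 to compound 2 (0.04 log units; within the scatter), the step is expected to be a 1.1-fold higher number from compound 3 to compound 4 (0.02 log units; within the scatter). Compound 4 is therefore estimated at 19000 nM, between 9000 nM and 40000 nM.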

Compound 4, concentration for 50% growth inhibition: 12000 nM
Compound 4: middle estimate off by 1.6-fold (0.20 log units), on the high side; the range from low to high includes it.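

In this assay chloro in place of bromo on an aromatic carbon gave a 1.5-fold lower number from compound 3 to compound 4 (0.18 log units; within the scatter) on this second core. Set beside the earlier step, the result on the two cores does not differ beyond the scatter: the same change on two cores in this assay, a 1.1-fold higher number (0.04 log units; within the scatter) from compound 1 to compound 2 and a 1.5-fold lower number (0.18 log units; within the scatter) from compound 3 to compound 4, 1.6-fold (0.21 log units) apart, within the scatter of two such steps. The exchange of these two halogens therefore carries from one core to the other without a measurable difference in this assay, but with both steps within the scatter, it does not show that the change has an effect of its own on either core.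

The compounds shown carry only bromo or chloro on the aromatic ring, so a nitrile or a methoxy group there remains open. Also open, going by these compounds, is how a carboxylic acid or an amide in place of the methyl ester would read.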